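This account rests on a few compounds, and the source may have more. Where it says the series, first, only, none or still open, it means among the compounds named here.

Series notes, aryl ketone variation.

Compound 1 `COc1cc(-c2cc(/C=C/C(=O)c3ccc(N)cc3)[nH]n2)cc(OC)c1OC` gives 83% in a functional assay on T47D cells (Homo sapiens) for cytotoxicity, read by sulforhodamine B assay, with a stated time of 48 h, tested at 0.01 uM; on this read-out lower numbers stand for a stronger effect and higher numbers for a weaker effect at the one concentration tested. Compound 2 `COc1ccc(C(=O)/C=C/c2cc(-c3cc(OC)c(OC)c(OC)c3)n[nH]2)cc1OC` gives 93% in this assay, and compound 3 `COc1ccc(C(=O)/C=C/c2cc(-c3cc(OC)c(OC)c(OC)c3)n[nH]2)cc1` gives 96% in this assay. On these numbers compound 3 stands at the top of the three, but only the gap to compound 1 is beyond the scatter, the step of a number 13 percentage points higher from compound 1 to compound 3 (beyond the scatter); the step of a number 3 percentage points higher from compound 2 to compound 3 (within the scatter) is within it, as is the step of a number 10 percentage points higher from compound 1 to compound 2 (within the scatter).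

Compound 4 `COc1cc(-c2cc(/C=C/C(=O)c3ccc(F)c(F)c3)[nH]n2)cc(OC)c1OC` is the next member; it differs from compound 3 by 3,4-difluorophenyl in place of 4-methoxyphenyl on a carbonyl carbon. All three measured steps concern the ring on the carbonyl carbon, so they bear on this change, though none of them puts fluorine there. Their sizes run from within the scatter to modest, and the larger one involves the amino group, which is absent from both compound 3 and compound 4. For compound 4 the expected step of a number 3 percentage points lower from compound 3 to compound 4 (within the scatter) in this assay is therefore small, with no firm direction beyond the scatter. Compound 4 is estimated at 93% in this assay, with a range from 80% to 104%.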

Compound 4, a percentage reported as activity, at one concentration (the size of the read-out at that concentration, not a potency): 95%
The estimate for compound 4 lay 2 percentage points below the measured number, within the range that was stated.
By their numbers in this assay, from the lowest: compounds 1, 2, 4 and 3 (each within the scatter of the next, the first and the last beyond it).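

In this assay, the first fluorinated ring on the carbonyl carbon leaves the reading where the methoxy-bearing rings put it, with a number 1 percentage points lower from compound 3 to compound 4 (within the scatter) and a number 2 percentage points higher from compound 2 to compound 4 (within the scatter), so 3,4-difluorophenyl cannot be told apart from 4-methoxyphenyl or 3,4-dimethoxyphenyl at this position. The 4-aminophenyl ring of compound 1 is now separated from a second ring type, with a number 12 percentage points higher from compound 1 to compound 4 (beyond the scatter), but this separation is modest and does not hold for every ring, as compound 2 goes against it with a number 10 percentage points higher from compound 1 to compound 2 (within the scatter). No measurement at hand accounts for these numbers.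

Whether the lower number of compound 1 belongs to the amino group itself stays open, since the compounds shown include no dimethylamino, acetamido or hydroxy group on this ring to test it. Also open, as far as these compounds go, is whether a carboxylic acid on the ring, or a pyridine in place of it, would move the reading beyond the scatter of compound 3 and compound 4 at this single concentration.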